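Swapping Methyl for Chloro on the Benzyl Ring

The source may hold more compounds than are shown below. What is called first, only, known or untested is meant among the compounds shown, and "the series" means these compounds.

Two measured compounds set the scene. Compound 1 `Cc1cc(-c2ccccc2)n(/C(N)=N/S(=O)(=O)c2cc(C)c(Cl)cc2SCc2ccccc2C(F)(F)F)n1` and compound 2 `Cc1cccc(CSc2cc(Cl)c(C)cc2S(=O)(=O)/N=C(\N)n2nccc2-c2ccccc2)c1` have both been tested. In a functional assay on HeLa cells (Homo sapiens) for cytotoxicity, read by MTT assay, with a stated time of 72 h (on this read-out higher numbers stand for weaker inhibition and lower numbers for stronger inhibition), compound 1 gives 215000 nM, while compound 2 gives 8000 nM. Of these two numbers, compound 2 holds the lower one, and its distance from compound 1 lies beyond the usual scatter, so compound 2 is the stronger inhibitor of the pair. Compound 3 `Cc1cc(S(=O)(=O)/N=C(\N)n2nccc2-c2ccccc2)c(SCc2cccc(Cl)c2)cc1Cl` has not yet been measured in this assay. It differs from compound 2 in a single place: chloro in place of methyl on an aromatic carbon. No measured step of this kind exists among these compounds, so the direction of the change in this assay is open, and a step no larger than the scatter, in either direction, is expected. Compound 3 is therefore estimated at 8000 nM, with a range from 3000 nM to 25000 nM, which amounts to an expected step of no change at the digits printed from compound 2 to compound 3 (within the scatter).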

Compound 3, half-maximal inhibitory concentration: 10000 nM
For compound 3 the middle estimate is 1.3-fold (0.10 log units) below the measured one; measured number inside the range.
By their numbers in this assay, from the lowest: compounds 2 and 3 (each within the scatter of the next); then compound 1.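

In this assay, replacing the 3-methylbenzyl group of compound 2 with the 3-chlorobenzyl group of compound 3 gives a 1.3-fold higher number from compound 2 to compound 3 (0.10 log units; within the scatter). Among these compounds, this is the first measured step at this position, and it shows that chloro and methyl cannot be told apart here on this read-out, since the two compounds lie within the scatter of repeated measurements. Nothing available here accounts for this result, so the pair records the outcome without offering an explanation.

The compounds shown leave open how this position would respond to a group of a different kind, such as an amine, a carboxylic acid or a longer chain. This single pair also cannot say whether the same swap would give a similar result elsewhere on the shared core.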